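This account rests on a few compounds, and the source may have more. Where it says the series, first, only, none or still open, it means among the compounds named here.

Measured compounds:
- compound 1, `Cc1c(OCCCCOc2ccc(Cl)c(C(=O)O)c2)ccc(C(=O)CC(C)(C)C)c1O` — 87 nM
- compound 2, `Cc1ccc(OCCCCOc2ccc(C(=O)CC(C)(C)C)c(O)c2C)cc1C(=O)O` — 210 nM

In an assay for positive allosteric modulation of metabotropic glutamate receptor 2 (Rattus norvegicus) (a higher number here means that more compound is needed for the effect, a lower number that less compound is needed), compound 1 gives 87 nM and compound 2 gives 210 nM. Going by the values given here, compound 2 thus stands at the higher of the two numbers; its nearest neighbour is compound 1, and the only step in the set is a 2.4-fold higher number from compound 1 to compound 2 (0.38 log units; beyond the scatter).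

Compound 3, `COc1ccc(OCCCCOc2ccc(C(=O)CC(C)(C)C)c(O)c2C)cc1C(=O)O`, is not yet measured. It differs from compound 2 in one place: methoxy in place of methyl on an aromatic carbon. The change sits on the same aromatic carbon that carried chloro in compound 1 and methyl in compound 2, ortho to a carboxy group.

Among the compounds with values here, no measured step bears on a methoxy at this position. Within the data shown here, the one step available, a 2.4-fold higher number from compound 1 to compound 2 (0.38 log units; beyond the scatter), shows that swapping the substituent here moved the number only modestly, so a third substituent at the same carbon is expected to stay in a similar range. For compound 3 the expected step is therefore a 1.2-fold higher number from compound 2 to compound 3 (0.08 log units; within the scatter), with no clear direction beyond the scatter, and the estimate in this assay is 250 nM, within 90 nM to 700 nM.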

Compound 3, half-maximal effective concentration: 13 nM
For compound 3 the middle estimate is 19-fold (1.28 log units) above the measured one, outside the stated range (below it).
By their numbers in this assay, from the lowest: compound 3; then compound 1; then compound 2.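

On this aromatic carbon, ortho to a carboxy group and para to a large group, the choice of substituent matters far more than a 2.4-fold higher number from compound 1 to compound 2 (0.38 log units; beyond the scatter) alone suggested. In this assay, methoxy in place of methyl gives a 16-fold lower number from compound 2 to compound 3 (1.21 log units; beyond the scatter) and methoxy in place of chloro gives a 6.7-fold lower number from compound 1 to compound 3 (0.83 log units; beyond the scatter), so the position is sensitive to this change and compound 3 holds the lowest number of the three, with both of its steps beyond the scatter. Nothing in the data accounts for the size of these steps.

As far as these compounds go, it remains open whether the lower number needs the whole methoxy group or only an oxygen on this carbon, and a hydroxy, an ethoxy or a longer alkoxy chain here would bear on that question. From the compounds shown here alone, it is equally open whether the effect of methoxy depends on the neighbouring carboxy group, which a tetrazole or an amide in its place would test, and whether it holds with other linkers in the shared core.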